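Chloro on the benzimidazole ring of a hydantoin antagonist

The source may hold more compounds than are shown below. What is called first, only, known or untested is meant among the compounds shown, and "the series" means these compounds.

Compound 1 `CC(=O)N1CCC(C[C@@H](c2nc3ccc(Cl)cc3n2C)N2C(=O)CN(c3ccc(Oc4ccccc4)cc3)C2=O)CC1`: in an assay on cells for antagonist activity at Bile acid receptor (Homo sapiens), read by a luciferase reporter, with a stated time of 24 h (a lower number here means a stronger inhibitor, a higher number a weaker inhibitor), compound 1 gives 0.8 nM.
Compound 2 `CC(C)C(=O)N1CCC(C[C@@H](c2nc3ccccc3n2C)N2C(=O)CN(c3ccc(Oc4ccccc4)cc3)C2=O)CC1`: in this assay compound 2 gives < 0.001 nM, which is a limit of the assay and not a number.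

Compound 2 thus stands at the floor of what this assay can report; the evidence for it is only that (the limit of < 0.001 nM in this assay, at which 1 of the 2 values shown sits). Compound 1 differs from compound 2 in two places at once, so its value shows only that it lies well above that limit.

Compound 3 `CC(C)C(=O)N1CCC(C[C@@H](c2nc3ccc(Cl)cc3n2C)N2C(=O)CN(c3ccc(Oc4ccccc4)cc3)C2=O)CC1` follows from compound 2 by chloro in place of hydrogen on an aromatic carbon. Going by the values given here, no single measured step describes this change. Given that compound 2 sits at the limit < 0.001 nM, the outcome for compound 3 may again be only a limit, or a small number; a step of an at least 10-fold higher number from compound 2 to compound 3 (1.00 log units; beyond the scatter) is expected, within or near the scatter. Compound 3 is estimated at 0.01 nM, in the range 0.0005 nM to 1 nM.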

Compound 3, half-maximal inhibitory concentration: 0.05 nM
Compound 3: the middle estimate sits 5.0-fold (0.70 log units) below what was measured; the range from low to high includes it.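

In this assay, going from the 1-methyl-1H-benzimidazol-2-yl group to the 6-chloro-1-methyl-1H-benzimidazol-2-yl group gives an at least 50-fold higher number from compound 2 to compound 3 (1.69 log units; beyond the scatter), so this position responds to chloro in place of hydrogen, and the inhibitor becomes weaker. One end of that step is the value of compound 2, which is a limit of the assay and not a number, so the step fixes only the smallest possible size of the change: the limit of < 0.001 nM in this assay, at which 1 of the 3 values shown sits. With the chloro held in place, isopropyl in place of methyl on a carbonyl carbon gives a 16-fold lower number from compound 1 to compound 3 (1.20 log units; beyond the scatter), which separates this change from the chloro change that compound 1 carries with it when set against compound 2.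

The compounds shown leave open how fluoro, methoxy or an amine at this position would compare with chloro. They also leave open whether a longer chain on that carbonyl carbon would extend the step seen with isopropyl.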